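The compounds below may be only part of what the source reports. "The series", "measured", "known", "first", "only" and "open" are said of these compounds alone.

The shared core carries an amide to an aromatic ring and a (furan-2-yl)carbonyl group on a ring nitrogen. Compound 1 `O=C(Nc1ccccc1)c1cc2n(n1)CCCN(C(=O)c1ccco1)C2` has the unsubstituted furan-2-yl, and in an ADME assay on BEAS-2B cells (Homo sapiens) for cytotoxicity, read by fluorescence, with a stated time of 48 h (on this read-out lower numbers stand for higher toxicity in this test and higher numbers for lower toxicity in this test), compound 1 is recorded as "not determined" (no result reported). Compound 3 `O=C(Nc1ccccc1)c1cc2n(n1)CCCN(C(=O)c1occc1-c1ccccc1)C2` is likewise recorded in this assay as "not determined" (no result reported). Compound 2 `O=C(Nc1ccccc1)c1cc2n(n1)CCCN(C(=O)c1occc1Cl)C2` is the only one of the three with a figure: in this assay compound 2 gives 30000 nM. Compound 4 `CCc1ccoc1C(=O)N1CCCn2nc(C(=O)Nc3ccccc3)cc2C1` differs from compound 1 by ethyl in place of hydrogen on an aromatic carbon. For the measured compounds named here, since compound 1 carries no number, no step can be computed, and the expectation for compound 4 rests on the value of compound 2 alone. In this assay the step from compound 1 to compound 4 is expected to be small, within the usual scatter, in no clear direction. Compound 4 is expected to give about 30000 nM in this assay, within 10000 nM to 90000 nM.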

Compound 4, half-maximal cytotoxic concentration: 10000 nM
Compound 4: the middle estimate sits 3.0-fold (0.48 log units) above what was measured; the measured number falls inside the stated range.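

For the compounds shown here, exchanging chloro for ethyl on this aromatic carbon of the furan gives the first readable comparison at this position in this assay, with a 3.0-fold lower number from compound 2 to compound 4 (0.48 log units; beyond the scatter) and thus a modest sensitivity to which of these two groups sits there. The steps from compound 1 and compound 3 cannot be read, so ethyl cannot be set against hydrogen or phenyl. Nothing at hand explains the step. Still open, on these data alone, is whether a longer chain such as propyl, or an amine, on this carbon would lower the number further or raise it.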